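A few compounds are considered here, and "the series" means these few. Any claim that something is new, unique, unknown or untested is made for them only; others in the source may bear on it.

Compound 1 `Cc1ccc(C(=O)Nc2nc3cc(C)cc(C)c3s2)cc1` gives 2.37 ug/mL in a functional assay on NUGC-3 cells (Homo sapiens) for antiproliferative activity, read by sulforhodamine B assay; on this read-out lower numbers stand for stronger inhibition of growth and higher numbers for weaker inhibition of growth.
Compound 2 `O=C(Nc1ccccc1)Nc1nc2ccc(F)cc2s1` gives only a limit, > 10 ug/mL, in this assay.
Compound 3 `O=C(Nc1cccc([N+](=O)[O-])c1)Nc1nc2ccc(F)cc2s1` gives 0.83 ug/mL in this assay.

Among the two numbers shown, compound 3 has the lower one, and compound 1 sits higher; for compound 2 only the limit of > 10 ug/mL in this assay, at which 1 of the 3 values shown sits, is known, so it cannot be placed as a number. Compound 4 `O=C(Nc1cccc([N+](=O)[O-])c1)Nc1nc2ccc(Cl)cc2s1` is still unmeasured; it differs from compound 3 by chloro in place of fluoro on an aromatic carbon. Going by the values given here, the one measured step, an at least 12-fold lower number from compound 2 to compound 3 (1.08 log units; beyond the scatter), concerns a nitro group in place of hydrogen at another part of the molecule and says nothing about swapping one halogen for another. Among the compounds with values here, no measured pair shows what chloro in place of fluoro does here. Because an at least 12-fold lower number from compound 2 to compound 3 (1.08 log units; beyond the scatter) does not touch the halogen, the expectation for compound 4 rests only on the fact that a single small group is exchanged for another of the same kind, and the expected step of a 1.2-fold lower number from compound 3 to compound 4 (0.07 log units; within the scatter) is none beyond the scatter. Compound 4 is therefore estimated at 0.7 ug/mL, within 0.3 ug/mL to 1.7 ug/mL.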

Compound 4, concentration for 50% growth inhibition: 1.03 ug/mL
Estimate against measurement, compound 4: 1.5-fold (0.17 log units) below, within the range that was stated.
By their numbers in this assay, from the lowest: compounds 3 and 4 (each within the scatter of the next); then compound 1. At a limit, above all of these: compound 2.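

Chloro in place of fluoro is the first change at this position of the shared core to be measured, on the six-membered aromatic ring of the fused system, and in this assay it gives a 1.2-fold higher number from compound 3 to compound 4 (0.09 log units; within the scatter). With the nitro group kept in place, either halogen therefore serves equally well here, and the two compounds cannot be told apart in this assay, so this position accepts a larger halogen atom without any readable loss of growth inhibition. Going by these compounds alone, nothing measured so far bears on why the two halogens read alike.

As far as these compounds go, it remains open whether a group of another kind at this position, such as an amine, a methoxy group or a carboxylic acid, would keep the number this low. From the compounds shown here alone, it is also open whether the same halogen exchange would read alike on a molecule lacking the nitro group.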